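The source may hold more compounds than are shown below. What is called first, only, known or untested is meant among the compounds shown, and "the series" means these compounds.

Compound 1 `O=C(CN1C(=O)CSC1=O)NOCc1ccccc1` stands in an ADME assay on RAW264.7 cells (Mus musculus) for cytotoxicity, read by neutral red uptake, with a stated time of 24 h (on this read-out lower numbers stand for higher toxicity in this test and higher numbers for lower toxicity in this test), only as a limit, with compound 1 at > 128000 nM. Compound 2 `C=CCONC(=O)CN1C(=O)CSC1=O` is also a limit, with compound 2 at > 128000 nM. Among the compounds with values here, the single measured step is a step that the two limits leave unreadable from compound 1 to compound 2, and the evidence so far is the limit of > 128000 nM in this assay, at which 2 of the 2 values shown sit. Compound 3 `CC(C(=O)NOCc1ccccc1)N1C(=O)CSC1=O` carries methyl in place of hydrogen on a saturated chain carbon bound to an amide-type nitrogen in a ring and a carbonyl carbon. Within the data shown here, no measured step concerns that place. The expected step is a step that the limit leaves unreadable from compound 1 to compound 3, none beyond the scatter. For compound 3 the estimated value is 140000 nM, with an expected range from 50000 nM to 300000 nM.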

Compound 3, half-maximal cytotoxic concentration: > 128000 nM
Compound 3 ended at the assay's limit; the forecaster's own chance of this, stated with the estimate: 75%; the middle value lies beyond the limit too.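

No step can be read between compound 1 and compound 3, as both values are limits: the limit of > 128000 nM in this assay, at which 3 of the 3 values shown sit. The compounds shown leave open whether methyl in place of hydrogen changes the read-out at all.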